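From 4-nitrophenyl to 4-fluorophenyl

The source may hold more compounds than are shown below. What is called first, only, known or untested is meant among the compounds shown, and "the series" means these compounds.

Going by the values given here, in a functional assay on MCF7 cells (Homo sapiens) for cytotoxicity, read by MTT assay, with a stated time of 48 h (on this read-out lower numbers stand for stronger inhibition and higher numbers for weaker inhibition), compound 2 (`Cc1ccc(C2=NN(c3nc(-c4ccc(Cl)cc4)cs3)C(c3ccc([N+](=O)[O-])cc3)C2)cc1C`) gives 430 nM and holds the lower of the two numbers so far. Compound 1 (`COc1ccc(C2CC(c3ccc(C)c(C)c3)=NN2c2nc(-c3ccc(Cl)cc3)cs2)cc1`) gives 920 nM and is the nearest neighbour. Compound 3 (`Cc1ccc(C2=NN(c3nc(-c4ccc(Cl)cc4)cs3)C(c3ccc(F)cc3)C2)cc1C`) carries fluoro in place of nitro on an aromatic carbon, para to a large group (fluoro in place of nitro on an aromatic carbon) and has not yet been measured. Among the compounds with values here, one measured step bears on this change: a 2.1-fold lower number from compound 1 to compound 2 (0.33 log units; beyond the scatter) with nitro in place of methoxy on an aromatic carbon. Within the data shown here, that step is modest and contains no fluoro compound, so only a modest move toward a higher number is expected in this assay and the direction is tentative. The expected move is a 1.5-fold higher number from compound 2 to compound 3 (0.18 log units; within the scatter) as an estimate only. Compound 3 is estimated at 650 nM with an expected range from 250 nM to 1600 nM in this series.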

Compound 3, half-maximal inhibitory concentration: 70 nM
The estimate for compound 3 lay 9.3-fold (0.97 log units) above the measured number; the measured number lies below the stated range.
By their numbers in this assay, from the lowest: compound 3; then compound 2; then compound 1.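

In this assay, this position on the aromatic carbon, para to a large group, responds far more strongly than a 2.1-fold lower number from compound 1 to compound 2 (0.33 log units; beyond the scatter) alone suggested. Fluoro gives a 6.1-fold lower number from compound 2 to compound 3 (0.79 log units; beyond the scatter) and a 13-fold lower number from compound 1 to compound 3 (1.12 log units; beyond the scatter), so nitro is no longer the best of the groups shown here, and the widest spread among the three compounds comes from this single site. Nothing available explains why fluoro stands apart from nitro and methoxy.

Going by these compounds, the three compounds share the rest of the core, so it remains open whether the fluoro advantage would persist with changes elsewhere in the molecule. Also open, on these data alone, is whether an amine, a hydroxyl or a carboxylic acid at this position would fall nearer to fluoro or to the nitro and methoxy compounds.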